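Aryl exchange from compound 3 to compound 4

The source may report more compounds than this note shows. Statements on the series, on what has been measured and on what is new or still open speak of the compounds shown alone.

In a functional assay on KB cells (Homo sapiens) for antiproliferative activity, read by sulforhodamine B assay, with a stated time of 3 days (on this read-out higher numbers stand for an effect only at larger amounts of compound and lower numbers for an effect already at smaller amounts), compound 1 `CCC1=C(O)c2c(oc(-c3ccc(F)cc3)cc2=O)C(CC)(CC)C1=O` gives 33 uM and compound 2 `CCC1=C(O)c2c(oc(-c3ccccc3C)cc2=O)C(CC)(CC)C1=O` gives 40.9 uM while compound 3 `CCC1=C(O)c2c(oc(-c3ccc(C)cc3C)cc2=O)C(CC)(CC)C1=O` gives 41.2 uM (within the scatter of both others). The next structure is compound 4 `CCC1=C(O)c2c(oc(-c3ccc(C)c(Cl)c3)cc2=O)C(CC)(CC)C1=O` with 3-chloro-4-methylphenyl in place of 2,4-dimethylphenyl on an aromatic carbon and the remainder unchanged.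

Among the compounds with values here, three measured steps bear on this exchange. Replacing the aryl group gave a 1.2-fold higher number from compound 1 to compound 2 (0.09 log units; within the scatter) and a 1.2-fold higher number from compound 1 to compound 3 (0.10 log units; within the scatter) while adding a methyl gave a 1.0-fold higher number from compound 2 to compound 3 (0.00 log units; within the scatter) so none of the three leaves the scatter. No chlorine-bearing aryl group has been measured in this series, which leaves the range wide. In this assay no step beyond the scatter is therefore expected, and the estimated step is a 1.2-fold lower number from compound 3 to compound 4 (0.07 log units; within the scatter) as a working figure only. Compound 4 is expected at 35 uM with an estimated range of 15 uM to 70 uM around it.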

Compound 4, concentration for half-maximal effect: 39 uM
Compound 4: middle estimate off by 1.1-fold (0.05 log units), on the low side, and the stated range covers the measured number.
By their numbers in this assay, from the lowest: compounds 1, 4, 2 and 3 (each within the scatter of the next).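

In this assay the chlorine-bearing aryl group, new to the series, stays within the scatter of every earlier compound: the exchange gives a 1.1-fold lower number from compound 3 to compound 4 (0.02 log units; within the scatter) and the other two comparisons give a 1.0-fold lower number from compound 2 to compound 4 (0.02 log units; within the scatter) and a 1.2-fold higher number from compound 1 to compound 4 (0.07 log units; within the scatter) on the same read-out. All four aryl groups shown on this aromatic carbon next to the ring oxygen, namely 4-fluorophenyl, 2-methylphenyl, 2,4-dimethylphenyl and 3-chloro-4-methylphenyl, therefore cannot be ordered by their numbers, and a chlorine shows no separate effect here. Nothing available explains this flat picture.

Still open, on these data alone, is whether an aryl group carrying an amine or a carboxylic acid would leave the scatter. Also open, as far as these compounds go, is whether a longer chain in place of the aryl group would do so.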